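The source may report more compounds than this note shows. Statements on the series, on what has been measured and on what is new or still open speak of the compounds shown alone.

Of the compounds shown here, three sharing one core have been measured in a functional assay on HT-1080 cells (Homo sapiens) for antiproliferative activity, read by sulforhodamine B assay, with a stated time of 48 h; a lower number here means a stronger inhibitor, a higher number a weaker inhibitor. Compound 1 `CCC(=O)Nc1ccc(S(=O)(=O)Oc2ccccc2I)cc1` gives 7200 nM. Compound 2 `O=C(CCl)Nc1ccc(S(=O)(=O)Oc2ccccc2I)cc1` gives 600 nM, and compound 3 `O=C(CCCl)Nc1ccc(S(=O)(=O)Oc2ccccc2I)cc1` gives 4200 nM. Among these three numbers compound 3 stands second highest: its number sits within the scatter of compound 1, as the step of a 1.7-fold lower number from compound 1 to compound 3 (0.23 log units; within the scatter) shows, while compound 2 lies clearly lower, as the steps of a 12-fold lower number from compound 1 to compound 2 (1.08 log units; beyond the scatter) and a 7.0-fold higher number from compound 2 to compound 3 (0.85 log units; beyond the scatter) show.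

Compound 4 `O=C(CCCCl)Nc1ccc(S(=O)(=O)Oc2ccccc2I)cc1` has not yet been measured. It differs from compound 3 by chloromethyl in place of chloro on a saturated chain carbon, two bonds along the chain from a carbonyl carbon. Going by the values given here, the measured step that most resembles this change is the one from compound 2 to compound 3, where the same exchange of chloromethyl for chloro, one bond closer to the carbonyl, gave a 7.0-fold higher number from compound 2 to compound 3 (0.85 log units; beyond the scatter). The step from compound 1 to compound 3 adds that a chloro at this outer place changed little. So in this assay compound 4 is expected to give a number like that of compound 3 or somewhat higher, an estimated step of a 1.5-fold higher number from compound 3 to compound 4 (0.19 log units; within the scatter). The estimate for compound 4 is 6500 nM, with a range from 2500 nM to 17000 nM.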

Compound 4, half-maximal inhibitory concentration: 12000 nM
Compound 4: the middle estimate sits 1.8-fold (0.27 log units) below what was measured, and the stated range covers the measured number.
By their numbers in this assay, from the lowest: compound 2; then compounds 3, 1 and 4 (each within the scatter of the next, the first and the last beyond it).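

In this assay, going by these compounds alone, moving the chloro one carbon further out along the chain again gives a higher number (a 2.9-fold higher number from compound 3 to compound 4 (0.46 log units; beyond the scatter)), so the exchange of chloro for chloromethyl still has an effect at this outer place, where a step beyond the scatter had not yet been seen. Compound 2, with its chloromethyl group on the carbonyl, stays far ahead of the 3-chloropropyl chain (a 20-fold higher number from compound 2 to compound 4 (1.30 log units; beyond the scatter)). The 3-chloropropyl chain also offers no gain over the unchlorinated chain (a 1.7-fold higher number from compound 1 to compound 4 (0.22 log units; within the scatter)), so among these compounds the clear advantage belongs to the shortest chloro chain alone. No measurement shown here accounts for these differences. From the compounds shown here alone, it remains open whether that advantage needs chlorine in particular, as a bromomethyl or hydroxymethyl group at the same place could show.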